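From a Cyclohexyl Ring to a Hexyl Chain

The compounds below may be only part of what the source reports. "The series", "measured", "known", "first", "only" and "open" are said of these compounds alone.

Measured in an ADME assay on MRC5 cells (Homo sapiens) for cytotoxicity, read by MTT assay; a lower number here means that less compound is tolerated, a higher number that more compound is tolerated:
- Compound 1 `C[Si](C)(C)C#Cc1c[nH]c(=O)[nH]c1=O`: 124000 nM
- Compound 2 `O=c1[nH]c(=O)n([C@@H]2O[C@H](CO)[C@@H](O)[C@H]2O)cc1C#CC1CCCCC1`: 36800 nM

Of these two compounds, compound 2 has the lower number, at 36800 nM. Its gap to compound 1, at 124000 nM, goes beyond the usual scatter of repeated measurements. The next compound to be tested is compound 3 `CCCCCCC#Cc1cn([C@@H]2O[C@H](CO)[C@@H](O)[C@H]2O)c(=O)[nH]c1=O`, which has hexyl in place of cyclohexyl on a triple-bonded carbon. The ring is opened into a chain, while the number of carbons in the group stays the same. Among the measured compounds shown here, no measured pair here differs in one place only, so the expectation rests on the structural change alone. In this assay, the expected step of a 1.2-fold lower number from compound 2 to compound 3 (0.09 log units; within the scatter) stays within the scatter. For compound 3, the estimated value is 30000 nM, with an expected range of 12000 nM to 75000 nM.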

Compound 3, half-maximal cytotoxic concentration: 15700 nM
Compound 3: middle estimate off by 1.9-fold (0.28 log units), on the high side; low and high end bracket the measured number.
By their numbers in this assay, from the lowest: compound 3; then compound 2; then compound 1.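

Opening the cyclohexyl ring into a hexyl chain on the triple-bonded carbon gives the first comparison here that differs in one place only, and in this assay it amounts to a 2.3-fold lower number from compound 2 to compound 3 (0.37 log units; beyond the scatter). The two groups match in their count of carbons, and neither brings hydrogen-bond donors or acceptors, so a ring and a chain of equal size are not interchangeable at this position, although the step is modest. Nothing measured here accounts for the step.

From the compounds shown here alone, whether a longer chain, a shorter chain such as butyl, or a hexyl chain ending in an amine would move the number further remains open. Compound 1 differs from compound 2 and compound 3 in more than one place, so this single pair cannot establish a trend.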